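This account rests on a few compounds, and the source may have more. Where it says the series, first, only, none or still open, it means among the compounds named here.

Working notes on the series.

Going by the values given here, compound 1 `O=C(CSc1nc(Nc2ccccc2)c2ccccc2n1)Nc1cccc(Br)c1` sits at the higher of the two numbers so far measured in a functional assay on MGC-803 cells (Homo sapiens) for inhibition, read by MTT assay, with a stated time of 72 h (a lower number here means a stronger inhibitor, a higher number a weaker inhibitor), where compound 1 gives 9620 nM. Among the compounds with values here, its nearest neighbour is compound 2 `C=CC(=O)Nc1cccc(NC(=O)CSc2nc(Nc3ccccc3)c3ccccc3n2)c1`, which in this assay gives 7310 nM; the only measured step is a 1.3-fold lower number from compound 1 to compound 2 (0.12 log units; within the scatter), a change at the aromatic ring on the amide-type nitrogen that left the number essentially where it was.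

Compound 3 `O=C(CSc1nc(Nc2ccccc2)c2ccccc2n1)Nc1ccc(Cl)c(Cl)c1` has not yet been measured in this assay. It differs from compound 1 as follows: 3,4-dichlorophenyl in place of 3-bromophenyl on an amide-type nitrogen. The shared core is untouched; the change sits on the amide-type nitrogen whose other neighbour is the carbonyl carbon.

Within the data shown here, the one step that bears on this position, a 1.3-fold lower number from compound 1 to compound 2 (0.12 log units; within the scatter), was within the scatter, and there is no measured halogen-for-halogen exchange in the set. The expectation for compound 3 is therefore a step of about a 1.1-fold lower number from compound 1 to compound 3 (0.03 log units; within the scatter), no further than the scatter reaches, in either direction. Compound 3 is estimated at 9000 nM in this assay, with a range from 3000 nM to 27000 nM.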

Compound 3, half-maximal inhibitory concentration: 37900 nM
For compound 3 the middle estimate is 4.2-fold (0.62 log units) below the measured one; the whole stated range lies below it.
By their numbers in this assay, from the lowest: compounds 2 and 1 (each within the scatter of the next); then compound 3.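

In this assay the aromatic group on the amide-type nitrogen proves able to move the number beyond the scatter: 3,4-dichlorophenyl in place of 3-bromophenyl gives a 3.9-fold higher number from compound 1 to compound 3 (0.60 log units; beyond the scatter), whereas the earlier step at this position stayed within the scatter. The same direction holds against the other earlier group, with 3,4-dichlorophenyl in place of 3-((vinylcarbonyl)amino)phenyl giving a 5.2-fold higher number from compound 2 to compound 3 (0.71 log units; beyond the scatter), so this position does respond to the choice of group even though compound 1 and compound 2 lie within the scatter of each other. Nothing available accounts for the higher number with 3,4-dichlorophenyl.

The change replaces bromine with chlorine and raises the count of halogen atoms from one to two in a single step, and the compounds shown do not separate these two parts of it. Also open, on these data alone, is whether any group at this position can bring the number well under those of compound 1 and compound 2, for example a phenyl ring with no halogen, or one carrying an amine or a carboxylic acid.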